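Compound 4 as a step from compound 1

The compounds below may be only part of what the source reports. "The series", "measured", "known", "first", "only" and "open" are said of these compounds alone.

Measured so far in a functional assay on DU-145 cells (Homo sapiens) for inhibition, read by trypan blue exclusion, with a stated time of 96 h; on this read-out lower numbers stand for stronger inhibition of growth and higher numbers for weaker inhibition of growth:
compound 1 `O=C(O)c1ccc(C(=O)/C(=C\c2ccc(F)c([N+](=O)[O-])c2)SCc2ccc(Cl)cc2Cl)cc1` gives 1000 nM
compound 2 `O=C(/C(=C\c1ccc([N+](=O)[O-])c(O)c1)S(=O)(=O)c1ccc(Br)cc1)c1c(F)c(F)c(F)c(F)c1F` gives 1000 nM
compound 3 `O=C(O)c1ccc(C(=O)/C(=C\c2ccc(Br)c([N+](=O)[O-])c2)SCc2ccc(Cl)cc2Cl)cc1` gives 1000 nM

Compound 1 stands level with compound 2 and compound 3, with all three reading the same value. Compound 4 `O=C(O)c1ccc(C(=O)/C(=C\c2ccc(F)c([N+](=O)[O-])c2)SCc2ccc(F)cc2)cc1` has not yet been measured, and it differs from compound 1 in one place: 4-fluorophenyl in place of 2,4-dichlorophenyl on a saturated chain carbon bound to a sulfur. In words, 4-fluorophenyl replaces 2,4-dichlorophenyl on a saturated chain carbon bound to a sulfur. Among the measured compounds shown here, the only measured step is no change at the digits printed from compound 1 to compound 3 (within the scatter), with bromo in place of fluoro on an aromatic carbon. For the measured compounds named here, that is a different place from the one changed here, and no step has been measured at the saturated chain carbon bound to a sulfur, so the guidance is thin. Resting on compound 1 at 1000 nM and on no change at the digits printed from compound 1 to compound 3 (within the scatter), no step beyond the scatter is expected in this assay, in either direction. The estimated step is no change at the digits printed from compound 1 to compound 4 (within the scatter) as an expectation only. Compound 4 is therefore expected at 1000 nM, with an estimated range of 400 nM to 2500 nM.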

Compound 4, concentration for 50% growth inhibition: 1000 nM
Compound 4: the middle estimate sits on the measured number at the digits printed; low and high end bracket the measured number.
By their numbers in this assay, from the lowest: compounds 1, 2, 3 and 4 (each within the scatter of the next).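

In this assay, exchanging 2,4-dichlorophenyl for 4-fluorophenyl on the saturated chain carbon bound to a sulfur gives no change at the digits printed from compound 1 to compound 4 (within the scatter). Among the compounds shown here, this is the first step read at this position, as the earlier step lay on an aromatic carbon, and it shows that the chlorine-bearing ring of compound 1 is not required to hold the value on this read-out. Nothing available explains this result or ties it to any feature of either group.

For the compounds shown here, only one exchange at this position can be read, so it remains open whether an unsubstituted phenyl, a pyridine ring or a simple methyl group would also leave the value unchanged. Going by these compounds, whether an amine or a longer chain placed there would shift growth inhibition in either direction also remains open.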